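A few compounds are considered here, and "the series" means these few. Any claim that something is new, unique, unknown or untested is made for them only; others in the source may bear on it.

Of the compounds shown here, three from one series have been tested so far. Compound 1 `CN(c1ccc(Oc2ncnc3sccc23)cc1)c1nccc(N2CCCCC2)n1` carries a methyl on the linking nitrogen and a piperidin-1-yl group; in a functional assay on MDA-MB-231 cells (Homo sapiens) for inhibition, read by MTT assay, with a stated time of 72 h, tested at 20 uM (a higher number here means more inhibition at the concentration tested (going by the name of the read-out), a lower number less inhibition), compound 1 gives 29.3%. Compound 3 `CN(c1ccc(Oc2ncnc3sccc23)cc1)c1nccc(N2CCc3ccccc3C2)n1` keeps that methylated nitrogen but bears a 1,2,3,4-tetrahydroisoquinolin-2-yl group in the same position; in this assay compound 3 gives 24.3%. The change between them, (piperidin-1-yl in place of 1,2,3,4-tetrahydroisoquinolin-2-yl on an aromatic carbon), produced a number 5 percentage points higher from compound 3 to compound 1 (within the scatter). Compound 2 `c1ccc2c(c1)CCN(c1ccnc(Nc3ccc(Oc4ncnc5ccsc45)cc3)n1)C2` shares the tetrahydroisoquinoline group of compound 3 but has an unsubstituted linking nitrogen; the difference between the two cores is not broken down here. In this assay compound 2 gives 15.4%, which stands within the scatter of the number for compound 3 and beyond it only relative to compound 1.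

Compound 4 `c1cc(N2CCCCC2)nc(Nc2ccc(Oc3ncnc4ccsc34)cc2)n1` has not yet been measured. It relates to compound 2 as compound 1 relates to compound 3, by piperidin-1-yl in place of 1,2,3,4-tetrahydroisoquinolin-2-yl on an aromatic carbon, the same change in the same place. Because the earlier instance of this change gave a number 5 percentage points higher from compound 3 to compound 1 (within the scatter), which was within the scatter, compound 4 is expected to move by about a number 4.6 percentage points higher from compound 2 to compound 4 (within the scatter), with the assumption that the unsubstituted linking nitrogen of compound 2 does not alter the effect of the exchange. On that basis compound 4 is estimated at 20% in this assay, with a likely range from 8% to 32%.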

Compound 4, a percentage reported as inhibition, at one concentration (the size of the read-out at that concentration, not a potency): 45.7%
Beside the measured number, compound 4's estimate is 25.7 percentage points below it; measured number outside the range, above it.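

In this assay, putting piperidin-1-yl in place of 1,2,3,4-tetrahydroisoquinolin-2-yl on the core of compound 2 produced a number 30.3 percentage points higher from compound 2 to compound 4 (beyond the scatter), a large step for a single exchange. The same exchange therefore did not carry over in size from one core to the other: the same change on two cores in this assay, a number 5 percentage points higher (within the scatter) from compound 3 to compound 1 and a number 30.3 percentage points higher (beyond the scatter) from compound 2 to compound 4, 25.3 percentage points apart, beyond the scatter of two such steps What this shows is that, in this series, a step measured on one core was a poor guide to the size of the same step on the other, so the earlier step cannot simply be transferred; what it does not show is which feature of the two cores sets the steps apart, since the cores are not broken down here, and one pair of steps gives no rule for any further core.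

The compounds shown leave open whether the methyl on the linking nitrogen, taken alone, would change the size of the step, as no pair here differs only in that place. They also leave open whether other amines in the same place, such as morpholin-4-yl or an open-chain dimethylamino group, would follow piperidin-1-yl on either core.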